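Swapping the Aryl Group on a Shared Core

The source may report more compounds than this note shows. Statements on the series, on what has been measured and on what is new or still open speak of the compounds shown alone.

Measured so far in a functional assay on MCF7 cells (Homo sapiens) for cytotoxicity, read by MTT assay, with a stated time of 72 h; a higher number here means a weaker inhibitor, a lower number a stronger inhibitor:
Compound 1 `O=C1C(=Cc2ccc(O)cc2)C(=O)N(c2ccc(Cl)cc2)N1c1ccc(Cl)cc1` gives 23200 nM.
Compound 2 `O=C1C(=Cc2ccc(Br)cc2)C(=O)N(c2ccc(Cl)cc2)N1c1ccc(Cl)cc1` gives 30400 nM.
Compound 3 `COc1cccc(C=C2C(=O)N(c3ccc(Cl)cc3)N(c3ccc(Cl)cc3)C2=O)c1O` gives 26700 nM.

All three share one core and differ only in the aryl group on a double-bonded chain carbon bound to a double-bonded ring carbon. Compound 2 stands close to both companions: the step of a 1.3-fold higher number from compound 1 to compound 2 (0.12 log units; within the scatter) and the step of a 1.1-fold lower number from compound 2 to compound 3 (0.06 log units; within the scatter) are each within the scatter, as is a 1.2-fold higher number from compound 1 to compound 3 (0.06 log units; within the scatter), so none of the three aryl swaps changed the number in a way that can be trusted.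

Compound 4 `O=C1C(=Cc2ccc(F)cc2F)C(=O)N(c2ccc(Cl)cc2)N1c1ccc(Cl)cc1` differs from compound 2 by the following change: 2,4-difluorophenyl in place of 4-bromophenyl on a double-bonded chain carbon bound to a double-bonded ring carbon. Among the compounds with values here, the steps that bear on this are the two aryl swaps already seen, a 1.3-fold higher number from compound 1 to compound 2 (0.12 log units; within the scatter) and a 1.1-fold lower number from compound 2 to compound 3 (0.06 log units; within the scatter), both small. On that basis the expected step of a 1.1-fold lower number from compound 2 to compound 4 (0.05 log units; within the scatter) is none beyond the scatter. Compound 4 is therefore expected to give about 27000 nM in this assay, with an estimated range from 12000 nM to 60000 nM.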

Compound 4, half-maximal inhibitory concentration: 22000 nM
For compound 4 the middle estimate is 1.2-fold (0.09 log units) above the measured one; the measured number falls inside the stated range.
By their numbers in this assay, from the lowest: compounds 4, 1, 3 and 2 (each within the scatter of the next).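

In this assay, within the data shown here, 2,4-difluorophenyl fits the pattern of the earlier aryl groups, with no step that can be trusted against any of them (a 1.4-fold lower number from compound 2 to compound 4 (0.14 log units; within the scatter)), (a 1.2-fold lower number from compound 3 to compound 4 (0.08 log units; within the scatter)) and (a 1.1-fold lower number from compound 1 to compound 4 (0.02 log units; within the scatter)). The position on the double-bonded chain carbon has now taken four different aryl groups, including one with two fluorine atoms, and the number has stayed within the scatter in every comparison shown. No measurement is available that bears on why these four aryl groups read alike.

Going by these compounds, all four compounds carry an aryl group at this place, so the effect of an amine, a carboxylic acid or a longer chain there remains open. Whether any change at this position can move the number beyond the scatter also remains unanswered.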